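A few compounds are considered here, and "the series" means these few. Any claim that something is new, unique, unknown or untested is made for them only; others in the source may bear on it.

Compound 1 `O=C(Nc1cc(-c2ccccc2)nn1-c1ccccc1)c1ccccc1` gives 40 nM in an assay on CHO cells with metabotropic glutamate receptor 5 (Homo sapiens) as the target; a lower number here means that less compound is needed, a higher number that more compound is needed for the effect.
Compound 2 `Cc1ccc(C(=O)Nc2cc(-c3ccccc3)nn2-c2ccccc2)cc1` gives 30 nM.
Compound 3 `O=C(Nc1cc(-c2ccccc2)nn1-c1ccccc1)c1ccc(F)cc1` gives 30 nM.

Compound 3 stands level with compound 2, the two together the lowest of the three numbers, and compound 1 is the furthest from it, though only by a 1.3-fold lower number from compound 1 to compound 3 (0.12 log units; within the scatter). The three compounds share one core and differ only in what sits on the benzamide ring.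

Compound 4 `Cc1ccccc1C(=O)Nc1cc(-c2ccccc2)nn1-c1ccccc1` has not yet been measured. It differs from compound 3 by 2-methylphenyl in place of 4-fluorophenyl on a carbonyl carbon. Going by the values given here, three measured steps touch this same ring, and all of them stay within the scatter: a 1.3-fold lower number from compound 1 to compound 2 (0.12 log units; within the scatter), a 1.3-fold lower number from compound 1 to compound 3 (0.12 log units; within the scatter), and no change at the digits printed from compound 2 to compound 3 (within the scatter). None of these steps places a methyl where 2-methylphenyl carries it, so they bear on the new change only loosely; what they do show is that this ring tolerated each change tried so far without a shift beyond the scatter. On that basis no step beyond the scatter is expected in this assay, with a somewhat wider range to reflect the untested placement. Compound 4 is therefore estimated at 40 nM, with a range from 15 nM to 120 nM. This estimate amounts to an expected step of a 1.3-fold higher number from compound 3 to compound 4 (0.12 log units; within the scatter).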

Compound 4, half-maximal effective concentration: > 10000 nM
Compound 4 was reported as a limit; the forecaster's own chance of this, stated with the estimate: 5%; at least 250-fold (2.39 log units) between middle value and limit.
By their numbers in this assay, from the lowest: compounds 2, 3 and 1 (each within the scatter of the next). At a limit, above all of these: compound 4.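

The reading for compound 4 in this assay is a limit and not a number: the limit of > 10000 nM in this assay, at which 1 of the 4 values shown sits. The clearest comparison is an at least 330-fold higher number from compound 2 to compound 4 (2.52 log units; beyond the scatter), since the two compounds carry the same methyl and differ only as 4-methylphenyl against 2-methylphenyl, so on this ring the place of the group matters, not just its presence. The other two steps, an at least 330-fold higher number from compound 3 to compound 4 (2.52 log units; beyond the scatter) and an at least 250-fold higher number from compound 1 to compound 4 (2.39 log units; beyond the scatter), agree with this and show that the tolerance seen among the first three compounds does not extend to every change on this ring.

Going by these compounds, it remains open whether a chlorine or a methoxy group, set where the methyl sits in 2-methylphenyl, would raise the number as well. The compounds shown also cannot tell how far the true value of compound 4 lies past its limit, or why the number rises.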